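From 1-hydroxyethyl to pyrazin-2-yl on a shared core

The source may report more compounds than this note shows. Statements on the series, on what has been measured and on what is new or still open speak of the compounds shown alone.

Compound 1 `CC(O)c1nc([C@@H](O)[C@H](O)[C@H](O)CO)c[nH]1` was followed in an ADME assay on the whole organism (strain 129/SvEvBrd x C57BL/6) for metabolic stability, with Mus musculus as the target (a higher number here means that the compound lasts longer, a lower number that the compound disappears faster), and gave 4.4 h in that measurement. Compound 2 `CC(=O)N/N=C(\C)c1nc([C@@H](O)[C@H](O)[C@H](O)CO)c[nH]1` gave 2.6 h there, and compound 3 `OC[C@@H](O)[C@@H](O)[C@H](O)c1c[nH]c(-c2ncn(Cc3ccccc3)n2)n1` gave 2.4 h on the same read-out. Compound 1 thus stands within the usual scatter of both others, and these numbers set no order among the three.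

Compound 4 `OC[C@@H](O)[C@@H](O)[C@H](O)c1c[nH]c(-c2cnccn2)n1` has not yet been measured. It carries pyrazin-2-yl in place of 1-hydroxyethyl on an aromatic carbon of the five-membered aromatic ring with 2 nitrogen, between two ring nitrogen atoms (pyrazin-2-yl in place of 1-hydroxyethyl on an aromatic carbon). Among the measured compounds shown here, no measured pair differs in one place only, so the data show no direct precedent for this change. The nearest guide is compound 3, which gave 2.4 h with a ring-bearing group on that same carbon, a value within the scatter of compound 1. On that basis, no step beyond the scatter is expected in this assay (a 1.7-fold lower number from compound 1 to compound 4 (0.23 log units; within the scatter)). For compound 4 the estimated half-life is 2.6 h with 1.3 h to 5 h as the expected range.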

Compound 4, half-life: 1.9 h
Beside the measured number, compound 4's estimate is 1.4-fold (0.14 log units) above it, within the range that was stated.
By their numbers in this assay, from the lowest: compounds 4, 3, 2 and 1 (each within the scatter of the next, the first and the last beyond it).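

Pyrazin-2-yl in place of 1-hydroxyethyl on this aromatic carbon, between two ring nitrogen atoms, gives in this assay the only change in one place that can be read here, with a 2.3-fold lower number from compound 1 to compound 4 (0.36 log units; beyond the scatter) as a modest step beyond the scatter. Among the compounds shown here, the earlier compounds offered no such pair, so this is the first sign that the group on this carbon can move the half-life at all, and the move runs downward for this exchange. The change has several parts, however: a chain with a hydrogen-bond donor and no ring gives way to a larger six-membered aromatic ring with no donor, and nothing shown tells how the step divides among these differences, nor does any available measurement explain why the number falls.

As far as these compounds go, what remains open is whether the hydroxyl of the 1-hydroxyethyl group or the pyrazine ring accounts for the step, which a 1-hydroxypropyl chain, an aminomethyl group or a phenyl ring on the same carbon could help to separate. Whether a carboxylic acid at this place would keep the half-life of compound 1 or lower it also stays unanswered.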